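Halogen swap on a phenyltriazole arm of an inactive series

This account rests on a few compounds, and the source may have more. Where it says the series, first, only, none or still open, it means among the compounds named here.

Three compounds share one core and differ only in the aryl group on the triazole nitrogen. Compound 1 `Cc1cccc(-n2nncc2CN2C(=O)C3(C(C#N)=C(N)Oc4c(N)cc5nc6ccccc6nc5c43)c3ccccc32)c1` carries a 3-methylphenyl, compound 2 `N#CC1=C(N)Oc2c(N)cc3nc4ccccc4nc3c2C12C(=O)N(Cc1cnnn1-c1ccc(F)cc1)c1ccccc12` a 4-fluorophenyl and compound 3 `N#CC1=C(N)Oc2c(N)cc3nc4ccccc4nc3c2C12C(=O)N(Cc1cnnn1-c1ccccc1Cl)c1ccccc12` a 2-chlorophenyl. In a functional assay on HCT-116 cells (Homo sapiens) for antiproliferative activity, read by MTT assay, with a stated time of 48 h (a lower number here means a stronger inhibitor, a higher number a weaker inhibitor), compound 1 gives > 50000 nM, which is a limit of the assay rather than a number. Compound 2 gives > 50000 nM in this assay, again a limit. Compound 3 gives > 50000 nM in this assay, also a limit. Because of the limit of > 50000 nM in this assay, at which 3 of the 3 values shown sit, the steps a step that the two limits leave unreadable from compound 1 to compound 2, a step that the two limits leave unreadable from compound 1 to compound 3 and a step that the two limits leave unreadable from compound 2 to compound 3 cannot be read in size or direction, so compound 3 stands simply at the limit, where the other two stand as well.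

Compound 4 `N#CC1=C(N)Oc2c(N)cc3nc4ccccc4nc3c2C12C(=O)N(Cc1cnnn1-c1ccccc1Br)c1ccccc12` is not yet measured. Its change from compound 3 is bromo in place of chloro on an aromatic carbon, a bromo in place of a chloro, on an aromatic carbon of a six-membered aromatic ring of carbon only. Among the compounds with values here, none of the measured steps gives a readable size for any aryl change, so no step beyond the scatter can be expected here, and the step that the limit leaves unreadable from compound 3 to compound 4 is estimated to leave compound 4 at the limit. Compound 4 is therefore expected to give about 80000 nM in this assay, within a range of 20000 nM to 300000 nM.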

Compound 4, half-maximal inhibitory concentration: 12400 nM
For compound 4 the middle estimate is 6.5-fold (0.81 log units) above the measured one; the measured number lies below the stated range.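

Within the data shown here, this aromatic carbon, ortho to a large group, is the first place where a change can be read in this assay: bromo in place of chloro gives an at least 4.0-fold lower number from compound 3 to compound 4 (0.60 log units; beyond the scatter). Neither group carries a hydrogen-bond donor, a hydrogen-bond acceptor or a net charge, yet the 2-bromophenyl group also sets compound 4 apart from the other two aryl arms, with an at least 4.0-fold lower number from compound 2 to compound 4 (0.60 log units; beyond the scatter) and an at least 4.0-fold lower number from compound 1 to compound 4 (0.60 log units; beyond the scatter). These steps give only a minimum size, and the steps among the first three compounds remain unreadable, because one or both ends of every step rest on a limit: the limit of > 50000 nM in this assay, at which 3 of the 4 values shown sit.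

Going by these compounds, whether iodo, methyl or methoxy on this same carbon would give a lower number than bromo remains open, as does whether bromo on another carbon of the ring would keep the gain. Among these compounds, with only one compound giving a measured number, no trend across the aryl groups can be drawn, and the size of the gain over the other three compounds remains unknown.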